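Replacing the 4-bromophenyl group of compound 3

A few compounds are considered here, and "the series" means these few. Any claim that something is new, unique, unknown or untested is made for them only; others in the source may bear on it.

Values in a functional assay on HepG2 cells (Homo sapiens) for antiproliferative activity, read by MTT assay, with a stated time of 48 h; on this read-out lower numbers stand for stronger inhibition and higher numbers for weaker inhibition:
- compound 1 `CN1CCN(CC(=O)Nc2ccc3ncnc(Nc4cccc(Cl)c4)c3c2)CC1`: > 100000 nM (a limit, not a number)
- compound 2 `CN1CCN(CC(=O)Nc2ccc3ncnc(Nc4cccc(Br)c4)c3c2)CC1`: 25300 nM
- compound 3 `CN1CCN(CC(=O)Nc2ccc3ncnc(Nc4ccc(Br)cc4)c3c2)CC1`: > 100000 nM (a limit, not a number)

Compound 3 gives > 100000 nM, which is a limit of this assay and not a number. It therefore sits at the limit of > 100000 nM in this assay, at which 2 of the 3 values shown sit.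

Compound 4 `CN1CCN(CC(=O)Nc2ccc3ncnc(Nc4ccc(Cl)c(C(F)(F)F)c4)c3c2)CC1` keeps the shared core and changes one group, on a nitrogen on an aromatic ring: 4-chloro-3-(trifluoromethyl)phenyl in place of 4-bromophenyl on a nitrogen on an aromatic ring. The 4-chloro-3-(trifluoromethyl)phenyl group thus replaces the 4-bromophenyl group.

Going by the values given here, two measured steps bear on this change. Exchanging 3-bromophenyl for 4-bromophenyl gave an at least 3.9-fold higher number from compound 2 to compound 3 (0.59 log units; beyond the scatter). Exchanging chloro for bromo gave an at least 3.9-fold lower number from compound 1 to compound 2 (0.59 log units; beyond the scatter). The third step, a step that the two limits leave unreadable from compound 1 to compound 3, adds nothing because both ends are limits. Among the compounds with values here, no measured step involves a trifluoromethyl group, so the guide is thin.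

In this assay, a modest move to a lower number is expected, though compound 4 may well stay at the limit. The expectation leans on compound 2, whose 3-bromophenyl group gave 25300 nM. The expected change is an at least 2.5-fold lower number from compound 3 to compound 4 (0.39 log units; beyond the scatter). For compound 4 the estimated value is 40000 nM, with an expected range from 10000 nM to 100000 nM.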

Compound 4, half-maximal inhibitory concentration: 25300 nM
Beside the measured number, compound 4's estimate is 1.6-fold (0.20 log units) above it; the measured number falls inside the stated range.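

In this assay, the 4-chloro-3-(trifluoromethyl)phenyl group on this nitrogen gives a readable number where the 4-bromophenyl group did not, with an at least 3.9-fold lower number from compound 3 to compound 4 (0.59 log units; beyond the scatter), and it does the same against the 3-chlorophenyl group, with an at least 3.9-fold lower number from compound 1 to compound 4 (0.59 log units; beyond the scatter). So a ring carrying a 4-substituent is not confined to the limit, and against the 3-bromophenyl group there is no change at the digits printed from compound 2 to compound 4 (within the scatter), which means two different rings now share the only readable value, while the 3-chlorophenyl group of compound 1 shows that a 3-substituent alone does not guarantee one. The two steps that start from a limit give only a minimum size, since compound 1 and compound 3 each carry a limit and not a number: the limit of > 100000 nM in this assay, at which 2 of the 4 values shown sit.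

The compounds shown leave open how much of the step from compound 3 belongs to the trifluoromethyl group and how much to chloro standing in place of bromo, as both differ in that one exchange. They also leave open what a ring bearing a nitrile, a methoxy group or an amine would give on this nitrogen.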